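This account rests on a few compounds, and the source may have more. Where it says the series, first, only, none or still open, it means among the compounds named here.

Compound 1 `OC[C@H]1O[C@@H](n2cnc3c(NCc4ccc(F)cc4)ncnc32)[C@H](O)[C@@H]1O` gives 1250 nM in a functional assay on CCRF-CEM cells (Homo sapiens) for antiproliferative activity, with a stated time of 72 h; a higher number here means a weaker inhibitor, a lower number a stronger inhibitor. Its analogue compound 2 `COc1cccc(CNc2ncnc3c2ncn3[C@@H]2O[C@H](CO)[C@@H](O)[C@H]2O)c1` gives 7600 nM in this assay, the step being a 6.1-fold higher number from compound 1 to compound 2 (0.78 log units; beyond the scatter). Among the two numbers known, compound 2 stands highest, with compound 1 the nearest at a markedly lower number. The unmeasured compound 3 `COc1cccc(CNc2ncnc3c2ncn3[C@@H]2O[C@H](CO)[C@@H](O)[C@H]2O)c1O` carries the change (hydroxy in place of hydrogen on an aromatic carbon). Among the measured compounds shown here, only one measured step exists here, and it describes an exchange of one aromatic substituent for another on the same ring rather than the addition of a hydroxy group, so it bears on compound 3 only loosely and gives no direction for this kind of change. An expectation for compound 3 therefore rests on little more than the number of compound 2 itself, with no step beyond the scatter expected, expressed as a 1.1-fold lower number from compound 2 to compound 3 (0.04 log units; within the scatter). Compound 3 is estimated at 7000 nM, within 2500 nM to 20000 nM.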

Compound 3, half-maximal inhibitory concentration: 300 nM
Compound 3: middle estimate off by 23-fold (1.37 log units), on the high side; measured number outside the range, below it.
By their numbers in this assay, from the lowest: compound 3; then compound 1; then compound 2.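

In this assay, a hydroxy on this aromatic carbon, ortho to a methoxy group and ortho to a large group, gives a 25-fold lower number from compound 2 to compound 3 (1.40 log units; beyond the scatter), which shows that this ring position, bearing hydrogen in compound 1 and compound 2, responds strongly to the change. The 2-hydroxy-3-methoxyphenyl group also fares better than the 4-fluorophenyl group, with a 4.2-fold lower number from compound 1 to compound 3 (0.62 log units; beyond the scatter), whereas 3-methoxyphenyl alone had gone the other way, with a 6.1-fold higher number from compound 1 to compound 2 (0.78 log units; beyond the scatter), so the hydroxy more than reverses that loss. Nothing measured here accounts for this gain.

Going by these compounds, whether the gain depends on the methoxy group of compound 3 remains open. So does whether an amine or a fluorine on the same aromatic carbon would match the hydroxy.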